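Does a ring at the chain end change activity?

The compounds below may be only part of what the source reports. "The series", "measured", "known", "first", "only" and "open" are said of these compounds alone.

Values in a functional assay on CCRF-CEM cells (Homo sapiens) for antiproliferative activity, read by MTT assay, with a stated time of 3 days; on this read-out higher numbers stand for weaker inhibition and lower numbers for stronger inhibition
- compound 1 `Cc1ccc(C#Cc2cn(C/C=C\CN3C(=O)c4ccccc4C3=O)c(=O)[nH]c2=O)cc1` gives 238000 nM
- compound 2 `CCCCCCCCC#Cc1cn(C/C=C\CN2C(=O)c3ccccc3C2=O)c(=O)[nH]c1=O` gives 39000 nM
- compound 3 `CCCCCC#Cc1cn(C/C=C/CN2C(=O)c3ccccc3C2=O)c(=O)[nH]c1=O` gives only the limit > 500000 nM

Compound 3 stands at the limit of > 500000 nM in this assay, at which 1 of the 3 values shown sits, and therefore has a limit rather than a true number.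

Compound 4 `O=C1c2ccccc2C(=O)N1C/C=C/Cn1cc(C#CCCc2ccccc2)c(=O)[nH]c1=O` differs from it by one change (phenyl in place of propyl on a saturated chain carbon, two bonds along the chain from a triple-bonded carbon), with phenyl in place of propyl on a saturated chain carbon, two bonds along the chain from a triple-bonded carbon.

Within the data shown here, only one measured step bears on this change, and it is modest (a 6.1-fold lower number from compound 1 to compound 2 (0.79 log units; beyond the scatter)). There, octyl takes the place of 4-methylphenyl on a triple-bonded carbon, which is a different place from the change in compound 4, so the guidance is loose. That step gives no reason to expect a ring to help, yet compound 1, which carries a ring, still gives a real number (238000 nM). A small move towards lower numbers is therefore expected in this assay, and compound 4 may also reach the limit.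

The expected change is small (an at least 1.4-fold lower number from compound 3 to compound 4 (0.15 log units; that floor lies within the scatter)).

The estimated value for compound 4 is 350000 nM (expected range 130000 nM to 900000 nM).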

Compound 4, half-maximal inhibitory concentration: 38000 nM
Beside the measured number, compound 4's estimate is 9.2-fold (0.96 log units) above it; measured number outside the range, below it.
By their numbers in this assay, from the lowest: compounds 4 and 2 (each within the scatter of the next); then compound 1. At a limit, above all of these: compound 3.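

In this assay, putting phenyl in place of propyl on a saturated chain carbon, two bonds along the chain from a triple-bonded carbon, gives an at least 13-fold lower number from compound 3 to compound 4 (1.11 log units; beyond the scatter). Among these compounds, this is the first direct sign that this part of the chain responds strongly to the group it carries, and that a ring at the chain end can turn a compound with no number into one with a measurable value. The true size of the step remains unknown, as the value for compound 3 is a limit and not a number: the limit of > 500000 nM in this assay, at which 1 of the 4 values shown sits.

Phenyl also brings more heavy atoms than propyl, so a longer chain such as hexyl at the same place would be needed to tell the ring apart from sheer size. Going by these compounds, how an amine or a carboxylic acid would behave there also remains open.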